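This account rests on a few compounds, and the source may have more. Where it says the series, first, only, none or still open, it means among the compounds named here.

Of the compounds shown here, three have been measured in a functional assay on the whole organism with Rattus norvegicus as the target; a lower number here means that less compound is needed, a higher number that more compound is needed for the effect. Compound 1 `CCCCCc1ccc2nc(N)sc2c1` gives 7.5 mg/kg in this assay, and compound 2 `CCCCCCc1ccc2nc(N)sc2c1` gives 7 mg/kg. These two differ by methyl in place of hydrogen on a saturated chain carbon, five bonds along the chain from an aromatic carbon, and the step of a 1.1-fold lower number from compound 1 to compound 2 (0.03 log units; within the scatter). Compound 3 `CCn1c(=N)sc2cc(OC(F)(F)F)ccc21` rests on a different core from compound 1; the difference between the two cores is not broken down here. In this assay compound 3 gives 5 mg/kg, a number that lies within the scatter of both compound 1 and compound 2.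

Compound 4 `CCCn1c(=N)sc2cc(OC(F)(F)F)ccc21` has not yet been measured. It differs from compound 3 by methyl in place of hydrogen on a saturated chain carbon, two bonds along the chain from an aromatic nitrogen. Among the measured compounds shown here, this is the same kind of change as the one from compound 1 to compound 2, but not the same change: there the methyl entered on a saturated chain carbon, five bonds along the chain from an aromatic carbon, here it enters on a saturated chain carbon, two bonds along the chain from an aromatic nitrogen. In this assay compound 4 is expected to show a step of a 1.1-fold lower number from compound 3 to compound 4 (0.05 log units; within the scatter) because the earlier instance of this kind of change gave a 1.1-fold lower number from compound 1 to compound 2 (0.03 log units; within the scatter). Compound 4 is therefore estimated at about 4.5 mg/kg, with a likely range from 2.5 mg/kg to 9 mg/kg.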

Compound 4, dose for half-maximal effect: 4.5 mg/kg
The estimate for compound 4 equals the measured number at the digits printed; the range from low to high includes it.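

In this assay, methyl in place of hydrogen on a saturated chain carbon, two bonds along the chain from an aromatic nitrogen, gives a 1.1-fold lower number from compound 3 to compound 4 (0.05 log units; within the scatter). This shows only that a single added methyl leaves the number within the scatter on these two cores; it does not show that the methyl has any effect of its own, and two instances, each at its own place on its own chain, do not make a rule for the whole series. Within those limits, the change carries from one core to the other without a detectable difference: the same change on two cores in this assay, a 1.1-fold lower number (0.03 log units; within the scatter) from compound 1 to compound 2 and a 1.1-fold lower number (0.05 log units; within the scatter) from compound 3 to compound 4, 1.0-fold (0.02 log units) apart, within the scatter of two such steps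

The compounds shown leave open whether a much longer chain, a branched chain such as isopropyl, or a chain ending in an amine or a carboxylic acid would stay within the scatter on either core. They also leave open whether the same holds for compound 3 and compound 4 once a chloro group stands in place of the trifluoromethoxy group.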